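Ester homologation on an isatin cinnamate scaffold

The source may report more compounds than this note shows. Statements on the series, on what has been measured and on what is new or still open speak of the compounds shown alone.

Compound 1 `COC(=O)/C=C/c1ccc2c(c1)C(=O)C(=O)N2C`: 250 nM
Compound 2 `COC(=O)/C=C/c1ccc2c(c1)C(=O)C(=O)N2Cc1ccc(C)cc1`: 50 nM
Compound 3 `COC(=O)/C=C/c1ccc2c(c1)C(=O)C(=O)N2Cc1ccc(OC)cc1`: 30 nM

The three compounds were measured in a functional assay on Jurkat cells (Homo sapiens) for antiproliferative activity, read by MTT assay, with a stated time of 48 h; on this read-out higher numbers stand for weaker inhibition and lower numbers for stronger inhibition. Compound 3 gives the lowest of the three numbers. Its nearest neighbour is compound 2, with a 1.7-fold lower number from compound 2 to compound 3 (0.22 log units; within the scatter), so the two cannot be ranked against each other. Compound 1 stands furthest away, with an 8.3-fold lower number from compound 1 to compound 3 (0.92 log units; beyond the scatter), and the parallel step a 5.0-fold lower number from compound 1 to compound 2 (0.70 log units; beyond the scatter) shows the same pattern for the other benzyl group.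

Compound 4 `CCOC(=O)/C=C/c1ccc2c(c1)C(=O)C(=O)N2Cc1ccc(OC)cc1` differs from compound 3 by methyl in place of hydrogen on a saturated chain carbon bound to an oxygen next to a carbonyl group, that is methoxycarbonyl to ethoxycarbonyl. Within the data shown here, none of the measured steps touches this position: all three concern the substituent on the saturated chain carbon bound to the amide-type nitrogen in the ring, and the ester has been the same in every compound measured so far. Among the measured compounds shown here, there is therefore no measured step that bears directly on the change, and the expectation rests on the absence of evidence rather than on a trend.

On that basis compound 4 is expected to give a number close to that of compound 3 in this assay, with an estimated step of no change at the digits printed from compound 3 to compound 4 (within the scatter), a change that is expected to stay within the scatter. The estimate for compound 4 is 30 nM, with a range from 12 nM to 75 nM.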

Compound 4, half-maximal inhibitory concentration: 30 nM
Beside the measured number, compound 4's estimate shows no gap at the digits printed; the measured number falls inside the stated range.
By their numbers in this assay, from the lowest: compounds 3, 4 and 2 (each within the scatter of the next); then compound 1.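

In this assay, among these compounds, the step from methoxycarbonyl to ethoxycarbonyl reads no change at the digits printed from compound 3 to compound 4 (within the scatter) and gives the first reading on this position, where methyl in place of hydrogen on a saturated chain carbon bound to an oxygen next to a carbonyl group leaves the number where it stood. The earlier compounds shown here all carried the same ester, so they showed only that the substituent on the other chain carbon matters, as in the step of an 8.3-fold lower number from compound 1 to compound 3 (0.92 log units; beyond the scatter) and this new step sets the ester change apart from that larger one. No measurement shown here gives a reason for this result.

On these data alone, whether the position accepts more than one added methyl stays open, as a longer chain such as a butyl ester, a branched isopropyl ester, a free carboxylic acid or an amide in place of the ester would each have to show. As far as these compounds go, the reading also rests on a single pair carrying 4-methoxyphenyl, so it remains open whether ethoxycarbonyl behaves alike with 4-methylphenyl or with the hydrogen of compound 1 on that chain carbon.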